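From 2-bromophenyl to 3-bromophenyl on the shared core

This account rests on a few compounds, and the source may have more. Where it says the series, first, only, none or still open, it means among the compounds named here.

In an ADME assay on Vero cells (Chlorocebus sabaeus) for cytotoxicity, read by MTT assay, with a stated time of 72 h (on this read-out higher numbers stand for an effect only at larger amounts of compound and lower numbers for an effect already at smaller amounts), compound 1 `O=C(Nc1nc(-c2ccccn2)cs1)c1cccc(OCc2ccccc2)c1` gives 14400 nM, and compound 3 `O=C(Nc1nc(-c2ccccn2)cs1)c1ccccc1Br` gives 3500 nM. For compound 2 `O=C(Nc1nc(-c2ccccn2)cs1)c1ccccc1O` there is no number, and its entry reads "not determined" (no result reported). Going by the values given here, compound 3 therefore holds the lower of only two numbers, and its gap to compound 1 lies beyond the scatter.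

Compound 4 `O=C(Nc1nc(-c2ccccn2)cs1)c1cccc(Br)c1` keeps the shared core and carries 3-bromophenyl in place of 2-bromophenyl on a carbonyl carbon. The two have the same atoms, joined differently. Among the compounds with values here, no measured pair shows a change of this kind, so the size of the step rests on thin evidence. Within the data shown here, a small rise in this assay is expected, possibly none beyond the scatter, as the only higher number is that of compound 1 at 14400 nM. The estimated 1.7-fold higher number from compound 3 to compound 4 (0.23 log units; within the scatter) is modest and upward. For compound 4 the expected value is 6000 nM, with an estimated range of 2000 nM to 18000 nM.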

Compound 4, half-maximal effective concentration: 16100 nM
Estimate against measurement, compound 4: 2.7-fold (0.43 log units) below, within the range that was stated.
By their numbers in this assay, from the lowest: compound 3; then compounds 1 and 4 (each within the scatter of the next).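

In this assay, going by these compounds alone, the place of the bromine alone matters on the shared core: 3-bromophenyl in place of 2-bromophenyl on a carbonyl carbon gives a 4.6-fold higher number from compound 3 to compound 4 (0.66 log units; beyond the scatter) with the same atoms on both sides, the first step that can be read for this change. Bromo in place of benzyloxy on an aromatic carbon gives a 1.1-fold higher number from compound 1 to compound 4 (0.05 log units; within the scatter) and so does not separate these two groups in this assay. Nothing at hand accounts for the difference between the two bromophenyl groups.

Going by these compounds, with a single pair, it remains open whether the lower number of compound 3 is specific to bromine or would also appear with 2-bromophenyl replaced by a ring carrying chlorine, a methyl group or an amine. Compound 2 has no number and adds no comparison.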